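From chloro to bromo on a shared core

The source may hold more compounds than are shown below. What is called first, only, known or untested is meant among the compounds shown, and "the series" means these compounds.

For the measured compounds named here, in a functional assay on the whole organism for antagonist activity, with Rattus norvegicus as the target (a higher number here means that more compound is needed for the effect, a lower number that less compound is needed), compound 2 `Cc1c(Cl)c[n+]([O-])c2nc(O)c(O)nc12` gives 7 mg/kg, the lower of the two numbers measured so far, while compound 1 `Cc1c(I)c[n+]([O-])c2nc(O)c(O)nc12` gives 30 mg/kg. The next compound, compound 3 `Cc1c(Br)c[n+]([O-])c2nc(O)c(O)nc12`, keeps the shared core and carries bromo in place of chloro on an aromatic carbon, ortho to a methyl group: bromo in place of chloro on an aromatic carbon. Going by the values given here, only one measured step bears on this change: a 4.3-fold lower number from compound 1 to compound 2 (0.63 log units; beyond the scatter), which is modest, lies beyond the scatter and swaps iodo for chloro at the same place. Bromo stands between chloro and iodo among the halogens, so a smaller step than that one is expected, towards a higher number in this assay. A single step fixes no trend, so the expectation stays loose. The estimated change is a 1.7-fold higher number from compound 2 to compound 3 (0.23 log units; within the scatter). The expected value for compound 3 is 12 mg/kg, with an estimated range from 5 mg/kg to 30 mg/kg.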

Compound 3, dose for half-maximal effect: 9 mg/kg
Beside the measured number, compound 3's estimate is 1.3-fold (0.12 log units) above it; the range from low to high includes it.
By their numbers in this assay, from the lowest: compounds 2 and 3 (each within the scatter of the next); then compound 1.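

In this assay the new step, a 1.3-fold higher number from compound 2 to compound 3 (0.11 log units; within the scatter), shows that bromo in place of chloro on this aromatic carbon, ortho to a methyl group, cannot be told apart from the chloro compound. The change from iodo is a different matter: the step of a 3.3-fold lower number from compound 1 to compound 3 (0.52 log units; beyond the scatter) is modest but beyond the scatter, so among these three halogens only iodo stands apart, with chloro and bromo together at the lower numbers. Nothing available here says why iodo separates from the other two.

On these data alone, whether fluoro would join chloro and bromo at this place remains open, and so does the effect of a group that is no halogen, such as an amine or a nitrile. As far as these compounds go, the three compounds also share the methyl group, so what a longer chain there would do is unknown.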